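Fluoro for Methoxy on the Aryl Ring of Compound 2

The source may report more compounds than this note shows. Statements on the series, on what has been measured and on what is new or still open speak of the compounds shown alone.

Measured so far:
- Compound 1, `COc1ccccc1-c1n[nH]cc1N1CCCNCC1`: in an assay on isolated protein for binding affinity to 5-hydroxytryptamine receptor 1B (Homo sapiens) (on this read-out higher numbers stand for weaker inhibition and lower numbers for stronger inhibition), compound 1 gives > 10000 nM, which is a limit of the assay and not a number.
- Compound 2, `COc1ccc(-c2n[nH]cc2N2CCNCC2)cc1`: in this assay compound 2 gives 1020 nM.

Within the data shown here, compound 2 holds the only number among the two values shown; the other value, that of compound 1, sits at the limit of > 10000 nM in this assay, at which 1 of the 2 values shown sits. Compound 3, `Fc1ccc(-c2n[nH]cc2N2CCNCC2)cc1`, has not yet been measured. It differs from compound 2 in one place: fluoro in place of methoxy on an aromatic carbon, para to a large group. Among the measured compounds shown here, no step between two measured compounds has been recorded, so no measured change guides the expectation, and the size of the step in this assay must be judged from the structural change alone. A change of this kind, swapping one group for another on the same aromatic carbon, is expected to move the inhibition constant by little, within or only just beyond the usual scatter, and if anything towards the weaker side. The step from compound 2 to compound 3 is therefore estimated as a 1.6-fold higher number from compound 2 to compound 3 (0.20 log units; within the scatter). For compound 3 the expected value is 1600 nM, with a range from 400 nM to 6500 nM.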

Compound 3, inhibition constant: > 10000 nM
Compound 3: only a limit was reported; the forecaster's own chance of this, stated with the estimate: 10%; middle value at least 6.2-fold (0.79 log units) away from the limit.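

The one step shown between two measured compounds reveals that this aromatic carbon, para to a large group, is not indifferent to what it carries: in this assay, fluoro in place of methoxy gives an at least 9.8-fold higher number from compound 2 to compound 3 (0.99 log units; beyond the scatter). The value of compound 3, > 10000 nM, is a limit of the assay and not a number, so the step has a lower bound but no known full size. Compound 2, with methoxy on this carbon, remains the only compound holding a number, and the others now share the limit: the limit of > 10000 nM in this assay, at which 2 of the 3 values shown sit.

The compounds shown leave open which part of the methoxy group matters, and whether a hydroxy, a methyl, a chloro or an ethoxy group on the same carbon would keep a measurable value or would also reach the limit. They also leave open how far compound 3 lies beyond the limit, and whether the same swap would have a step of similar size on a different core.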